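Swapping the aryl on the ring amine: what to expect

The compounds below may be only part of what the source reports. "The series", "measured", "known", "first", "only" and "open" are said of these compounds alone.

Measured so far:
compound 1, `Nc1scc(CN2CCN(c3cccc(C(F)(F)F)c3)CC2)c1C(=O)c1ccc(Cl)cc1`, 0%
compound 2, `Nc1scc(CN2CCN(c3cccc(F)c3)CC2)c1C(=O)c1cccc(C(F)(F)F)c1`, 0%

In an assay on CHO cells for displacement of a labelled ligand from adenosine receptor A3 (Homo sapiens), read by scintillation counting, with a stated time of 120 min, tested at 10 uM (a lower number here means less inhibition, a higher number more inhibition at the concentration tested (going by the name of the read-out)), compound 1 gives 0%. Compound 2 gives 0% in this assay, so the two measured compounds stand level at the digits shown, within the usual scatter, and neither number can be called the higher. Among the measured compounds shown here, no pair among the measured compounds differs in only one place, so no single structural step has yet been measured.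

Compound 3, `Nc1scc(CN2CCN(c3cc(F)ccc3F)CC2)c1C(=O)c1ccc(Cl)cc1`, has not yet been tested. It differs from compound 1 in one place: 2,5-difluorophenyl in place of 3-(trifluoromethyl)phenyl on an amine nitrogen in a ring.

For the measured compounds named here, with no measured step to lean on, and since compound 1 gives 0% and compound 2 gives 0%, the expected step is a number 3 percentage points higher from compound 1 to compound 3 (within the scatter), meaning no change beyond the scatter. Compound 3 is therefore estimated at 3%, with a range from 0% to 20%.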

Compound 3, a percentage reported as inhibition, at one concentration (the size of the read-out at that concentration, not a potency): 2%
Beside the measured number, compound 3's estimate is 1 percentage points above it, within the range that was stated.
By their numbers in this assay, from the lowest: compounds 1, 2 and 3 (each within the scatter of the next).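

Putting 2,5-difluorophenyl in place of 3-(trifluoromethyl)phenyl on an amine nitrogen in a ring gives a number 2 percentage points higher from compound 1 to compound 3 (within the scatter) in this assay, a step that changes one place alone. At this position, then, going from a group of 10 heavy atoms to one of 8, with a different fluorine pattern, leaves the read-out unchanged within the scatter, and the core of compound 1 stays close to the bottom of the scale with either group. Nothing available offers an explanation for this result.

As far as these compounds go, whether any group on this ring nitrogen can raise the read-out remains open. A phenyl ring carrying an amine or a carboxylic acid, or a plain methyl group in place of the aryl, could read differently or just the same.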